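Moving the Methoxy Group on an Anilino Quinone Core

The source may report more compounds than this note shows. Statements on the series, on what has been measured and on what is new or still open speak of the compounds shown alone.

Compound 2 `COc1ccccc1NC1=CC(=O)c2nc3n(c2C1=O)[C@H]1OC[C@@H](O)[C@H]1OC3` stands at a limit of a functional assay on MCF7 cells (Homo sapiens) for inhibition, read by sulforhodamine B assay; a lower number here means a stronger inhibitor, a higher number a weaker inhibitor: in this assay compound 2 gives > 4000 nM, a limit rather than a number. Compound 1 `O=C1C(Nc2ccccc2)=CC(=O)c2c1nc1n2[C@H]2OC[C@@H](O)[C@H]2OC1` likewise gives only a limit, > 4000 nM. Compound 3 `COc1cccc(NC2=CC(=O)c3c(nc4n3[C@H]3OC[C@@H](O)[C@H]3OC4)C2=O)c1` gives 3830 nM, and the step of an at least 1.0-fold lower number from compound 1 to compound 3 (0.01 log units; that floor lies within the scatter) came with methoxy in place of hydrogen on an aromatic carbon. Compound 4 `COc1cccc(NC2=CC(=O)c3nc4n(c3C2=O)[C@H]2OC[C@@H](O)[C@H]2OC4)c1` differs from compound 2 by 3-methoxyphenyl in place of 2-methoxyphenyl on an amine nitrogen. Among the measured compounds shown here, the only measured step that bears on this change is the one from compound 1 to compound 3, whose size lay within the scatter; with the limit of > 4000 nM in this assay, at which 2 of the 3 values shown sit, in view, no gain beyond the scatter is expected. The account estimates for compound 4 a value of 4000 nM (2000 nM to 8000 nM). This corresponds to an expected step of a number no higher from compound 2 to compound 4 (the limit leaves the size open).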

Compound 4, half-maximal inhibitory concentration: > 4000 nM
Compound 4: only a limit was reported; the forecaster's own chance of this, stated with the estimate: 60%; the middle value sits exactly at the limit.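

Compound 2 and compound 4 both give only a limit in this assay, so no step between them can be read: the limit of > 4000 nM in this assay, at which 3 of the 4 values shown sit.

The compounds shown leave open how far 3-methoxyphenyl and 2-methoxyphenyl on this amine nitrogen differ in inhibition.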